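A few compounds are considered here, and "the series" means these few. Any claim that something is new, unique, unknown or untested is made for them only; others in the source may bear on it.

Compound 1 `O=C(O)C[C@H](NC(=O)CCCCc1ccc2c(n1)NCCC2)c1cnc2ccccc2c1`: in a functional assay for inhibition, with Homo sapiens as the target (on this read-out higher numbers stand for weaker inhibition and lower numbers for stronger inhibition), compound 1 gives 4440 nM.
Compound 2 `O=C(O)C[C@H](NC(=O)CCCCc1ccc2c(n1)NCCC2)c1ccc2c(c1)OCC2`: in this assay compound 2 gives > 10000 nM, which is a limit of the assay and not a number.
Compound 3 `O=C(O)C[C@H](NC(=O)CCCCc1ccc2c(n1)NCCC2)c1cccc(F)c1`: in this assay compound 3 gives > 10000 nM, again a limit of the assay rather than a number.

All three share one core and differ only in the aromatic group on a saturated chain carbon bound to an amide-type nitrogen and a saturated chain carbon. Compound 1 alone has a readable number; compound 3 sits at the limit, as does compound 2 (the limit of > 10000 nM in this assay, at which 2 of the 3 values shown sit). The step of an at least 2.2-fold higher number from compound 1 to compound 3 (0.35 log units; beyond the scatter) and the step of an at least 2.2-fold higher number from compound 1 to compound 2 (0.35 log units; beyond the scatter) both run toward weaker inhibition, whereas the step that the two limits leave unreadable from compound 2 to compound 3 is not readable.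

Compound 4 `O=C(O)C[C@H](NC(=O)CCCCc1ccc2c(n1)NCCC2)c1cncnc1` carries pyrimidin-5-yl in place of 3-fluorophenyl on a saturated chain carbon bound to an amide-type nitrogen and a saturated chain carbon. For the measured compounds named here, no measured step makes this exchange. Going by the values given here, the only compound with a readable number, compound 1, also carries a six-membered aromatic ring with a hetero atom, at 4440 nM, which leaves open a modest gain in this assay. Compound 4 is therefore estimated at 12000 nM, within 3000 nM to 40000 nM. The step that the limit leaves unreadable from compound 3 to compound 4 is expected to be small, with a fair chance that only a limit is reported.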

Compound 4, half-maximal inhibitory concentration: > 10000 nM
Compound 4 gave a limit, no number; the forecaster's own chance of this, stated with the estimate: 55%; the middle value is on the limit's open side.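

Pyrimidin-5-yl, the smallest group shown at this place, brings no readable inhibition: in this assay compound 4 gives > 10000 nM, which is a limit of the assay and not a number. Exchanging quinolin-3-yl for pyrimidin-5-yl gives an at least 2.2-fold higher number from compound 1 to compound 4 (0.35 log units; beyond the scatter), so a hetero atom in an aromatic ring does not by itself keep the activity of compound 1. The steps among compound 2, compound 3 and compound 4 cannot be read, and quinolin-3-yl remains the only group here with a readable number: the limit of > 10000 nM in this assay, at which 3 of the 4 values shown sit.

On these data alone, how compound 2, compound 3 and compound 4 rank beyond the limit stays open. Also open, as far as these compounds go, is whether naphthalen-2-yl, with two aromatic rings of carbon only, would read like quinolin-3-yl at this place.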